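Methyl to Fluoro: Expected Cytotoxicity of Compound 3

This account rests on a few compounds, and the source may have more. Where it says the series, first, only, none or still open, it means among the compounds named here.

Compound 1 `COc1ccc(/C=C/C(=O)c2c(C)[n+]([O-])c3ccccc3[n+]2[O-])cc1`: 93000 nM
Compound 2 `Cc1ccc(/C=C/C(=O)c2c(C)[n+]([O-])c3ccccc3[n+]2[O-])cc1`: 23000 nM

In an ADME assay on HPLF cells (Homo sapiens) for cytotoxicity, with a stated time of 48 h (a higher number here means that more compound is tolerated, a lower number that less compound is tolerated), compound 1 gives 93000 nM and compound 2 gives 23000 nM, so compound 2 stands lowest of the two numbers. Compound 3 `Cc1c(C(=O)/C=C/c2ccc(F)cc2)[n+]([O-])c2ccccc2[n+]1[O-]` carries fluoro in place of methyl on an aromatic carbon, at a place para to a large group. Going by the values given here, the only measured step, a 4.0-fold lower number from compound 1 to compound 2 (0.61 log units; beyond the scatter), sits at the same place but swaps a different pair of groups, so it bears only loosely on this change. A modest shift in either direction, or none beyond the scatter, is plausible. For compound 3 the expected value is 35000 nM, within 12000 nM to 100000 nM, which means an expected step of a 1.5-fold higher number from compound 2 to compound 3 (0.18 log units; within the scatter).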

Compound 3, half-maximal cytotoxic concentration: 20000 nM
Compound 3: middle estimate off by 1.8-fold (0.24 log units), on the high side; measured number inside the range.
By their numbers in this assay, from the lowest: compounds 3 and 2 (each within the scatter of the next); then compound 1.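

In this assay, on the aromatic carbon para to a large group, fluoro in place of methyl gives a 1.2-fold lower number from compound 2 to compound 3 (0.06 log units; within the scatter), so this change leaves the number within the scatter. Methoxy alone stands apart here: a 4.7-fold lower number from compound 1 to compound 3 (0.67 log units; beyond the scatter), much like a 4.0-fold lower number from compound 1 to compound 2 (0.61 log units; beyond the scatter), and fluoro and methyl end up together on the same side of it. No measured evidence here bears on this result. The compounds shown leave open whether chloro, hydroxyl, an amine or a carboxylic acid at this place would stay with methyl and fluoro or side with methoxy.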